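Swapping a Methoxy Side Chain for a Cyclobutyl Ring

The compounds below may be only part of what the source reports. "The series", "measured", "known", "first", "only" and "open" are said of these compounds alone.

The study measures an ADME assay on Huh-7 cells (Homo sapiens) for cytotoxicity, with a stated time of 72 h; a lower number here means that less compound is tolerated, a higher number that more compound is tolerated. Going by the values given here, compound 1, with the structure `CCC(C)(C)c1nn(CCC(C)C)c(=O)c(C2=NS(=O)(=O)c3cc(NS(C)(=O)=O)ccc3N2)c1O`, is one of two compounds measured so far. In this assay compound 1 reaches only the limit > 1000 nM, which is a ceiling of the measurement rather than a number. Compound 2, with the structure `COC(C)(C)CCn1nc(-c2cccs2)c(O)c(C2=NS(=O)(=O)c3cc(NS(C)(=O)=O)ccc3N2)c1=O`, is the starting point here. In this assay compound 2 likewise gives only the limit > 33000 nM, so it sits at one of the two limits on record, as the limit of > 33000 nM in this assay, at which 1 of the 2 values shown sits, shows. Compound 3, with the structure `CS(=O)(=O)Nc1ccc2c(c1)S(=O)(=O)N=C(c1c(O)c(-c3cccs3)nn(CCC3CCC3)c1=O)N2`, has not yet been measured. It differs from compound 2 by cyclobutyl in place of 1-methoxy-1-methylethyl on a saturated chain carbon, two bonds along the chain from an aromatic nitrogen. Among the compounds with values here, no measured step between compounds is available, so any expectation rests only on these limits. The step from compound 2 to compound 3 is expected to stay within the usual scatter, an at least 1.1-fold lower number from compound 2 to compound 3 (0.04 log units; that floor lies within the scatter). Compound 3 is therefore estimated at 30000 nM, within a range from 8000 nM to 100000 nM, most likely reported again as a limit.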

Compound 3, half-maximal cytotoxic concentration: > 1000 nM
Compound 3 was reported as a limit; the forecaster's own chance of this, stated with the estimate: 70%; the middle value lies beyond the limit too.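

Going by these compounds alone, compound 2 and compound 3 both stand only as limits in this assay, and no step between them can be read. The compounds shown leave open whether cyclobutyl in place of 1-methoxy-1-methylethyl changes the concentration tolerated at all, and by how much.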